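A few compounds are considered here, and "the series" means these few. Any claim that something is new, unique, unknown or untested is made for them only; others in the source may bear on it.

Measured compounds:
compound 1 `O=C(Nc1cccc(-n2cc(-c3ccncc3)c(-c3ccc(Cl)c(O)c3)n2)c1)Nc1cccc(C(F)(F)F)c1` — 2020 nM
compound 2 `COc1cc(-c2nn(-c3cccc(NC(=O)Nc4ccc(Cl)c(C(F)(F)F)c4)c3)cc2-c2ccncc2)ccc1Cl` — 1010 nM

In a functional assay on SK-MEL-2 cells (Homo sapiens) for inhibition, read by sulforhodamine B assay, with a stated time of 48 h (a lower number here means a stronger inhibitor of growth, a higher number a weaker inhibitor of growth), compound 1 gives 2020 nM. In the same assay compound 2 gives 1010 nM; this is the lower of the two numbers, but the gap to compound 1 lies within the scatter of repeated measurements, so no order between the two can be claimed.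

Compound 3 `O=C(Nc1cccc(-n2cc(-c3ccncc3)c(-c3ccc(Cl)c(O)c3)n2)c1)Nc1ccc(Cl)c(C(F)(F)F)c1` is not yet measured. It differs from compound 2 in one place: hydrogen in place of methyl on an oxygen on an aromatic ring — hydrogen in place of methyl on an oxygen on an aromatic ring, read one bond further out as methoxy to hydroxy, 4-chloro-3-methoxyphenyl to 4-chloro-3-hydroxyphenyl.

Among the measured compounds shown here, no step between two measured compounds covers this change, so the size of the step in this assay cannot be read from the data. For the measured compounds named here, with only two values at hand, both within the scatter of each other, the step from compound 2 to compound 3 is expected to be no larger than the scatter, in no particular direction, a 1.5-fold higher number from compound 2 to compound 3 (0.17 log units; within the scatter). Compound 3 is therefore estimated at 1500 nM, within the range 600 nM to 4000 nM.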

Compound 3, concentration for 50% growth inhibition: 798 nM
Beside the measured number, compound 3's estimate is 1.9-fold (0.27 log units) above it, and the stated range covers the measured number.
By their numbers in this assay, from the lowest: compounds 3, 2 and 1 (each within the scatter of the next, the first and the last beyond it).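

Methoxy to hydroxy, 4-chloro-3-methoxyphenyl to 4-chloro-3-hydroxyphenyl, reads in this assay as a 1.3-fold lower number from compound 2 to compound 3 (0.10 log units; within the scatter), so the two groups cannot be told apart at this place in this pair. Chloro in place of hydrogen on an aromatic carbon gives a 2.5-fold lower number from compound 1 to compound 3 (0.40 log units; beyond the scatter), a modest step and the only single-place difference here that clears the scatter. No supporting measurement accompanies either step, so the data offer no explanation for their sizes.

From the compounds shown here alone, what an ethoxy group, an amine or a carboxylic acid would give at this place on the aromatic ring stays open. Going by these compounds, the chloro step rests on a single pair with hydroxy, so whether it holds with methoxy in that place also stays open.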